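Two chlorines and a fluorine on the phenyl ring of compound 1

A few compounds are considered here, and "the series" means these few. Any claim that something is new, unique, unknown or untested is made for them only; others in the source may bear on it.

Compound 1 `CC(C)(C)n1ncc(OCc2nnc(-c3c(F)cccc3F)o2)c(Cl)c1=O` stands at the low end of three numbers in a physicochemical assay for lipophilicity; a higher number here means a more lipophilic compound, a lower number a more polar compound: compound 1 gives 2.75, compound 2 `CC(C)(C)n1ncc(OCc2nnc(-c3ccccc3)o2)c(Cl)c1=O` gives 2.95, and compound 3 `CC(C)(C)n1ncc(OCc2nnc(-c3cc(F)c(F)c(F)c3F)o2)c(Cl)c1=O` gives 3.18. The gap from compound 1 to compound 2 lies within the scatter, while the gap to compound 3 lies beyond it. Compound 4 `CC(C)(C)n1ncc(OCc2nnc(-c3cc(F)c(Cl)cc3Cl)o2)c(Cl)c1=O` differs from compound 1 in one place: 2,4-dichloro-5-fluorophenyl in place of 2,6-difluorophenyl on an aromatic carbon. For the measured compounds named here, the only measured step that touches this place is a number 0.20 log units higher from compound 1 to compound 2 (within the scatter), and the numbers of compound 1 and compound 3 show that adding fluorines to the phenyl ring moved this assay only modestly. Going by the values given here, no measured step brings chlorine onto this ring, so the size of the step is uncertain, but two chlorines entering where two fluorines leave should carry compound 4 upward beyond the scatter. The account therefore expects compound 4 to give about 3.8 in this assay, within a range from 3.3 to 4.4. The expected step of a number 1.05 log units higher from compound 1 to compound 4 (beyond the scatter) is an estimate, not a measurement.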

Compound 4, partition coefficient: 3.36
The estimate for compound 4 lay 0.44 log units above the measured number; the measured number falls inside the stated range.
By their numbers in this assay, from the lowest: compounds 1, 2, 3 and 4 (each within the scatter of the next, the first and the last beyond it).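

Replacing 2,6-difluorophenyl with 2,4-dichloro-5-fluorophenyl, on the aromatic carbon next to the ring nitrogen and the ring oxygen, gives a number 0.61 log units higher from compound 1 to compound 4 (beyond the scatter) in this assay and is the first change shown to bring chlorine onto this phenyl ring. Starting from plain phenyl, the same group gives a number 0.41 log units higher from compound 2 to compound 4 (beyond the scatter) and so differs from the step between 2,6-difluorophenyl and phenyl, which stays within the scatter. Both new steps are modest in size, and nothing available accounts for them.

With only fluorine or chlorine on this ring, the compounds shown leave open how much of each step belongs to either chlorine and whether the fluorine contributes. Also open, on these data alone, is how the number would respond to an amine or a carboxylic acid on this ring.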